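The source may report more compounds than this note shows. Statements on the series, on what has been measured and on what is new or still open speak of the compounds shown alone.

Measured so far:
compound 1, `O=C1Nc2ccccc2/C1=N/NC(=S)Nc1cccc2ccccc12`, gives 5120 nM in a functional assay on KB 3-1 cells (Homo sapiens) for cytotoxicity, read by MTT assay, with a stated time of 72 h; on this read-out lower numbers stand for stronger inhibition and higher numbers for weaker inhibition
compound 2, `O=C1Nc2ccccc2/C1=N/NC(=S)NC1CCCCC1`, gives 9140 nM
compound 3, `COc1cc(NC(=S)N/N=C2\C(=O)Nc3ccccc32)cc(OC)c1OC`, gives 11100 nM

Compound 2 stands second highest of the three numbers; its nearest neighbour is compound 3 and its furthest is compound 1, and both gaps lie within the scatter. No two of these compounds differ in a single place, so the values give no shown step. Compound 4, `O=C1Nc2ccccc2/C1=N/NC(=S)Nc1ccc(F)cc1`, differs from compound 2 by 4-fluorophenyl in place of cyclohexyl on an amide-type nitrogen. The two aryl-bearing analogues already measured, compound 1 and compound 3, both sit within the scatter of compound 2, so no step beyond the scatter is expected in this assay in either direction. Compound 4 is therefore expected to give 7500 nM, within a range of 3000 nM to 18000 nM. The expected step is a 1.2-fold lower number from compound 2 to compound 4 (0.09 log units; within the scatter).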

Compound 4, half-maximal inhibitory concentration: 14200 nM
Compound 4: middle estimate off by 1.9-fold (0.28 log units), on the low side; the measured number falls inside the stated range.
By their numbers in this assay, from the lowest: compounds 1, 2, 3 and 4 (each within the scatter of the next, the first and the last beyond it).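

In this assay, going by these compounds alone, 4-fluorophenyl in place of cyclohexyl on an amide-type nitrogen gives a 1.6-fold higher number from compound 2 to compound 4 (0.19 log units; within the scatter) and is the first single-place comparison at this position. Here, an aromatic ring carrying fluorine and a non-aromatic carbon ring give numbers that cannot be told apart. No available evidence accounts for this result.

Plain phenyl would be needed to separate the ring change from the fluorine. From the compounds shown here alone, whether an amine, a carboxylic acid or a longer alkyl chain on this nitrogen gives a step beyond the scatter stays open.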